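The source may hold more compounds than are shown below. What is called first, only, known or untested is meant among the compounds shown, and "the series" means these compounds.

Compound 1 `O=C(NCCCCN1CCCCC1)Nc1ccc(-c2ccccc2)cc1`: 7900 nM in a functional assay on HEK293 cells for agonist activity at 5-hydroxytryptamine receptor 3A (Homo sapiens), read by FLIPR; on this read-out higher numbers stand for weaker inhibition and lower numbers for stronger inhibition
Compound 2 `O=C(NCCCCN1CCCCC1)Nc1ccc(-c2ccccc2F)cc1`: 5700 nM in this assay

Among the compounds with values here, only two compounds have been measured, and compound 2 stands within the scatter of compound 1: the step of a 1.4-fold lower number from compound 1 to compound 2 (0.14 log units; within the scatter) is too small to count as a real change, so neither compound can be called the stronger one. Compound 3 `COc1ccccc1-c1ccc(NC(=O)NCCCCN2CCCCC2)cc1` differs from compound 2 in one place: methoxy in place of fluoro on an aromatic carbon. Within the data shown here, the only measured step that bears on this change is a 1.4-fold lower number from compound 1 to compound 2 (0.14 log units; within the scatter), which put a fluoro at the same place and left the number essentially where it was. On that thin basis, replacing fluoro with methoxy is expected to give at most a small shift in this assay, with no clear direction. Compound 3 is therefore estimated to give 5000 nM, in a range from 2000 nM to 15000 nM. The expected step is a 1.1-fold lower number from compound 2 to compound 3 (0.06 log units; within the scatter).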

Compound 3, half-maximal inhibitory concentration: 7800 nM
The estimate for compound 3 lay 1.6-fold (0.19 log units) below the measured number, within the range that was stated.
By their numbers in this assay, from the lowest: compounds 2, 3 and 1 (each within the scatter of the next).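

In this assay, methoxy in place of fluoro on this aromatic carbon, ortho to a large group, gives a 1.4-fold higher number from compound 2 to compound 3 (0.14 log units; within the scatter) and methoxy in place of hydrogen gives a 1.0-fold lower number from compound 1 to compound 3 (0.01 log units; within the scatter) so neither step counts as a real change. Within the data shown here, the position now carries hydrogen, fluoro and methoxy with no real difference among them, and this holds even though methoxy is larger than fluoro by heavy atoms and brings a hydrogen-bond acceptor, something the single fluoro step could not show. No measurement is available to explain this result.

Going by these compounds, whether an amine, a carboxylic acid or a longer chain such as butoxy at this place would move the number beyond the scatter remains open. So does whether fluoro or methoxy would behave the same way on another carbon of this ring.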